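Propyl in Place of 4-Methylphenyl on the Carbonyl Carbon

A few compounds are considered here, and "the series" means these few. Any claim that something is new, unique, unknown or untested is made for them only; others in the source may bear on it.

Three measured compounds share one core and differ only in the group attached to the carbonyl carbon. Compound 1 `COc1ccc(C(=O)N2CCN(Cc3nc4ccccc4n3Cc3cccc(C)c3)CC2)cc1` gives 55.5% in an assay on isolated protein for inhibition of aldehyde dehydrogenase 1A1 (Homo sapiens), read by spectrophotometry, tested at 10 uM; on this read-out lower numbers stand for less inhibition and higher numbers for more inhibition at the one concentration tested (going by the name of the read-out). Compound 2 `Cc1cccc(Cn2c(CN3CCN(C(=O)c4cccs4)CC3)nc3ccccc32)c1` gives 60.8% in this assay. Compound 3 `Cc1ccc(C(=O)N2CCN(Cc3nc4ccccc4n3Cc3cccc(C)c3)CC2)cc1` gives 64.9% in this assay, the highest of the three numbers, although its gaps to the other two, a number 4.1 percentage points higher from compound 2 to compound 3 (within the scatter) and a number 9.4 percentage points higher from compound 1 to compound 3 (within the scatter), both lie within the scatter.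

Compound 4 `CCCC(=O)N1CCN(Cc2nc3ccccc3n2Cc2cccc(C)c2)CC1` carries the change (propyl in place of 4-methylphenyl on a carbonyl carbon). The measured steps that bear on it are the two that also exchange the group on the carbonyl carbon: a number 5.3 percentage points higher from compound 1 to compound 2 (within the scatter) and a number 4.1 percentage points higher from compound 2 to compound 3 (within the scatter), each within the scatter. Among the measured compounds shown here, no measured step exchanges an aromatic ring for a chain at this position, so that part of the change is untested. Since the carbonyl substituent has so far barely moved the number, the step expected in this assay is a number 7.9 percentage points lower from compound 3 to compound 4 (within the scatter), not beyond the scatter. Compound 4 is therefore estimated at 57%, with a range from 35% to 75%.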

Compound 4, a percentage reported as inhibition, at one concentration (the size of the read-out at that concentration, not a potency): 79.1%
The estimate for compound 4 lay 22.1 percentage points below the measured number, outside the stated range (above it).
By their numbers in this assay, from the lowest: compounds 1, 2 and 3 (each within the scatter of the next); then compound 4.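

At the carbonyl carbon, compounds 1, 2 and 3 stay within the scatter of one another in this assay, but propyl moves the number beyond the scatter against 4-methylphenyl (a number 14.2 percentage points higher from compound 3 to compound 4 (beyond the scatter)), against thiophen-2-yl (a number 18.3 percentage points higher from compound 2 to compound 4 (beyond the scatter)) and against 4-methoxyphenyl (a number 23.6 percentage points higher from compound 1 to compound 4 (beyond the scatter)). Among these four compounds, an aromatic ring on the carbonyl carbon is therefore not required for inhibition at the one concentration tested, and the chain gives the highest number. Nothing available explains why propyl gives this result.

The compounds shown leave open whether the gain comes from losing the aromatic ring or from the propyl chain itself, which a cyclohexyl ring, an ethyl group or a longer pentyl chain at this position could help separate. They also leave open how an amine or a carboxylic acid at the end of the chain would read in this assay.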